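The source may hold more compounds than are shown below. What is called first, only, known or untested is meant among the compounds shown, and "the series" means these compounds.

Compound 1 `COc1ccc([C@@H]2C/C(=N/OCc3cn(-c4ccc(Cl)cc4C)nn3)c3cc(CC=C(C)C)c(OC)cc3O2)cc1` is one of three compounds tested in a functional assay on MCF7 cells (Homo sapiens) for inhibition, read by sulforhodamine B assay, with a stated time of 48 h, tested at 50 uM; on this read-out lower numbers stand for less inhibition of growth and higher numbers for more inhibition of growth at the one concentration tested; in this assay compound 1 gives 37%. Compound 2 `COc1cc2c(cc1CC=C(C)C)C(=O)C[C@@H](c1ccc(Oc3ccc(F)cc3)cc1)O2` gives 37% in this assay, and compound 3 `COc1ccc([C@@H]2C/C(=N/OCc3cn(-c4ccc(C(=O)c5ccccc5)cc4)nn3)c3cc(CC=C(C)C)c(OC)cc3O2)cc1` gives 41%. Compound 1 thus stands level with compound 2, the two together at the bottom of the three numbers, while compound 3 lies a little higher but within the scatter, so no order among them can be claimed. Compound 4 `COc1ccc([C@@H]2C/C(=N/OCc3cn(-c4cccc(CO)c4)nn3)c3cc(CC=C(C)C)c(OC)cc3O2)cc1` differs from compound 1 in one place: 3-(hydroxymethyl)phenyl in place of 4-chloro-2-methylphenyl on an aromatic nitrogen. Among the measured compounds shown here, no step between measured compounds that differ in one place is available, so the size of the step from compound 1 to compound 4 cannot be read from the data; a change of this kind is expected to give a step of about a number 1 percentage points higher from compound 1 to compound 4 (within the scatter), that is, none beyond the scatter in either direction. Compound 4 is accordingly expected to give roughly 38% in this assay, with a plausible range from 22% to 55%.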

Compound 4, percent growth inhibition at one concentration: 42%
Compound 4: middle estimate off by 4 percentage points, on the low side, within the range that was stated.
By their numbers in this assay, from the lowest: compounds 1, 2, 3 and 4 (each within the scatter of the next).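

Replacing 4-chloro-2-methylphenyl with 3-(hydroxymethyl)phenyl on the aromatic nitrogen gives a number 5 percentage points higher from compound 1 to compound 4 (within the scatter) in this assay. This first one-place comparison shows that this position accepts the exchange, which brings in a hydrogen-bond donor and acceptor, without a change beyond the scatter. Nothing available explains this result. The compounds shown leave open whether an amine or a carboxylic acid on this phenyl ring, or a longer chain in place of hydroxymethyl, would move the number beyond the scatter.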